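The source may hold more compounds than are shown below. What is called first, only, known or untested is meant among the compounds shown, and "the series" means these compounds.

Compound 2, `CCN1CCCC1CNC(=O)c1cc(NS(N)(=O)=O)c(C)cc1OC`, is known only from a limit in a functional assay on the whole organism for inhibition, with Mus musculus as the target; a higher number here means that more compound is needed for the effect, a lower number that less compound is needed: at the reported dose it gives > 50 mg/kg, a limit of the assay and not a number. Compound 1, `CCN1CCCC1CNC(=O)c1cc(NS(=O)(=O)NC)c(Cl)cc1OC`, likewise reaches only a limit in this assay, where compound 1 gives > 50 mg/kg. Among the compounds with values here, both values thus sit at the limit of > 50 mg/kg in this assay, at which 2 of the 2 values shown sit, and there is no step between measured compounds from which the size of a change could be read.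

Compound 3, `CCN1CCCC1CNC(=O)c1cc(NS(N)(=O)=O)c(Cl)cc1OC`, differs from compound 2 by chloro in place of methyl on an aromatic carbon. Within the data shown here, with no measured step to lean on, the expectation for this assay rests on the two limits alone, and no step beyond the usual scatter in either direction is anticipated; the step from compound 2 to compound 3 is expected to be a number no higher from compound 2 to compound 3 (the limit leaves the size open). Compound 3 is therefore expected to give about 50 mg/kg in this assay, within a range of 20 mg/kg to 200 mg/kg, most likely again as a limit rather than a number.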

Compound 3, dose for half-maximal effect: > 50 mg/kg
Compound 3 ended at the assay's limit; the forecaster's own chance of this, stated with the estimate: 80%; the middle value lies on the limit itself.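

Compound 3 gives only a limit, as do compound 1 and compound 2, so neither step to compound 3 can be read in this assay: the limit of > 50 mg/kg in this assay, at which 3 of the 3 values shown sit.

The compounds shown leave open how much compound any of the three needs for the effect, and whether either change alters that dose.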